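The source may hold more compounds than are shown below. What is called first, only, known or untested is meant among the compounds shown, and "the series" means these compounds.

Three compounds from this series were tested in a toxicity assay on THP-1 cells (Homo sapiens) for inhibition; on this read-out lower numbers stand for higher toxicity in this test and higher numbers for lower toxicity in this test. Compound 1 `COc1ccc(-c2cnc(NC(=O)c3ccccn3)n2C)cc1` carries a pyridin-2-yl on the carbonyl carbon. In this assay compound 1 gives > 100000 nM, which is a limit of the assay and not a number. Compound 2 `Cn1c(-c2ccc(F)cc2)cnc1NC(=O)c1ccc(F)cc1` in this assay gives > 100000 nM, likewise a limit. Compound 3 `COc1ccccc1-c1cnc(NC(=O)c2ncc[nH]2)n1C` in this assay gives > 50000 nM, again a limit. Compound 1 thus stands where every measured value stands, at a limit: the limit of > 100000 nM in this assay, at which 2 of the 3 values shown sit, and (the limit of > 50000 nM in this assay, at which 1 of the 3 values shown sits). Going by the values given here, no step between two measured compounds can be drawn, since every value is a limit.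

Compound 4 `COc1ccc(C(=O)Nc2ncc(-c3ccc(OC)cc3)n2C)cc1` has not yet been measured in this assay. It differs from compound 1 in one place: 4-methoxyphenyl in place of pyridin-2-yl on a carbonyl carbon. The three measured compounds vary at this carbonyl substituent and at the aryl group on the core, and all sit at a limit. The step of a number no higher from compound 1 to compound 4 (the limit leaves the size open) is therefore expected to be none beyond the scatter. Compound 4 is expected to give about 100000 nM in this assay, with a range from 50000 nM to 300000 nM, and most likely only a limit will be reported.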

Compound 4, half-maximal cytotoxic concentration: > 100000 nM
Compound 4: only a limit was reported (the forecaster's own chance of this, stated with the estimate: 85%); the middle value sits exactly at the limit.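

In this assay, compound 1 and compound 4 both sit at a limit of the assay, and no step between them can be read: the limit of > 100000 nM in this assay, at which 3 of the 4 values shown sit.

The compounds shown leave open whether any change to the group on the carbonyl carbon would give a readable value.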